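From Cyclohexyl to Propyl on the Shared Core

The source may report more compounds than this note shows. Statements on the series, on what has been measured and on what is new or still open speak of the compounds shown alone.

Measured in a functional assay on A549 cells (Homo sapiens) for inhibition, read by MTT assay, with a stated time of 48 h; a lower number here means a stronger inhibitor, a higher number a weaker inhibitor:
Compound 1 `COc1cccc(C(c2c[nH]c3ccc(Br)cc23)c2c[nH]c3ccc(Br)cc23)c1OC` gives 100000 nM
Compound 2 `CN(C)c1ccc(C(c2c[nH]c3ccc(Br)cc23)c2c[nH]c3ccc(Br)cc23)cc1` gives 25000 nM
Compound 3 `Brc1ccc2[nH]cc(C(c3c[nH]c4ccc(Br)cc34)C3CCCCC3)c2c1` gives 5500 nM

These compounds share one core and differ only in the group on a saturated chain carbon bound to two aromatic carbons. Compound 3 is the strongest inhibitor of the three (it gives 5500 nM). Its cyclohexyl group outperforms both aromatic groups, with an 18-fold lower number from compound 1 to compound 3 (1.26 log units; beyond the scatter) and a 4.5-fold lower number from compound 2 to compound 3 (0.66 log units; beyond the scatter) as the evidence. The aromatic groups also differ from each other, with a 4.0-fold lower number from compound 1 to compound 2 (0.60 log units; beyond the scatter) as the step between them.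

Compound 4 `CCCC(c1c[nH]c2ccc(Br)cc12)c1c[nH]c2ccc(Br)cc12` has propyl in place of cyclohexyl on a saturated chain carbon bound to two aromatic carbons is the full difference. Among the measured compounds shown here, no measured compound carries an open chain, so these steps bear on the change only indirectly. Propyl, like cyclohexyl, is not aromatic, so a return toward compound 1 (at 100000 nM) is not expected. A slightly higher number is expected in this assay but nothing certain follows from the data. The expected change is a 1.5-fold higher number from compound 3 to compound 4 (0.16 log units; within the scatter) and is estimated to stay within the scatter. For compound 4 the estimated value is 8000 nM with an expected range from 3000 nM to 25000 nM in this assay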

Compound 4, half-maximal inhibitory concentration: 6500 nM
For compound 4 the middle estimate is 1.2-fold (0.09 log units) above the measured one; measured number inside the range.
By their numbers in this assay, from the lowest: compounds 3 and 4 (each within the scatter of the next); then compound 2; then compound 1.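

Propyl in place of cyclohexyl, on a saturated chain carbon bound to two aromatic carbons, gives no difference that can be separated from the scatter in this assay, with a 1.2-fold higher number from compound 3 to compound 4 (0.07 log units; within the scatter), even though propyl has no ring and fewer heavy atoms. A ring is therefore not required at this position for the lower numbers: the open chain also stands clear of both aromatic groups, with a 3.8-fold lower number from compound 2 to compound 4 (0.59 log units; beyond the scatter) and a 15-fold lower number from compound 1 to compound 4 (1.19 log units; beyond the scatter). Nothing measured here explains why these two non-aromatic groups give lower numbers than the two aromatic ones.

Going by these compounds, it remains open whether a shorter chain such as methyl or a longer chain such as hexyl would give a similar number. On these data alone, it is equally open what a propyl chain carrying an amine or a carboxylic acid would give.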